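Ring change at the limit of tolerated concentration

The source may report more compounds than this note shows. Statements on the series, on what has been measured and on what is new or still open speak of the compounds shown alone.

Compound 1 `CCC(C)Nc1cc(Oc2c(OC)cc3cc(C#N)ccc3c2OC)nc(Nc2ccc(C#N)cc2)n1`: > 125000 nM
Compound 2 `CCC(CC)Nc1cc(Oc2c(OC)cc3cc(C#N)ccc3c2OC)nc(Nc2ccc(C#N)cc2)n1`: > 125000 nM
Compound 3 `COc1cc2cc(C#N)ccc2c(OC)c1Oc1cc(NC2CCOCC2)nc(Nc2ccc(C#N)cc2)n1`: > 125000 nM

In an ADME assay on MT4 cells (Homo sapiens) for cytotoxicity, read by MTT assay, with a stated time of 5 days (a lower number here means that less compound is tolerated, a higher number that more compound is tolerated), all three compounds give only limits, not numbers, and they share (the limit of > 125000 nM in this assay, at which 3 of the 3 values shown sit). Compound 3 therefore stands at a limit, > 125000 nM, and not at a measured number. Compound 4 `COc1cc2cc(C#N)ccc2c(OC)c1Oc1cc(NCC2CCOC2)nc(Nc2ccc(C#N)cc2)n1` differs from it by one change: (oxolan-3-yl)methyl in place of oxan-4-yl on a nitrogen on an aromatic ring. The measured steps that bear on this change are a step that the two limits leave unreadable from compound 1 to compound 3 and a step that the two limits leave unreadable from compound 2 to compound 3. Neither has a size that can be read, and a step that the two limits leave unreadable from compound 1 to compound 2 adds none, so they suggest no direction. No step beyond the scatter is expected, and the expected step is a number no higher from compound 3 to compound 4 (the limit leaves the size open). Compound 4 is estimated at 125000 nM, with an expected range of 60000 nM to 250000 nM.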

Compound 4, half-maximal cytotoxic concentration: > 125000 nM
Compound 4 gave a limit, no number (the forecaster's own chance of this, stated with the estimate: 85%); the middle value sits exactly at the limit.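

Among these compounds, compound 4, like compound 1, compound 2 and compound 3, gives only a limit in this assay, and no step to compound 4 can be read. The compounds shown leave open whether (oxolan-3-yl)methyl in place of oxan-4-yl changes the tolerated concentration at all.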